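This account rests on a few compounds, and the source may have more. Where it says the series, first, only, none or still open, it means among the compounds named here.

Working notes on the dibenzoylhydrazine series, read in an assay on cells for agonist activity at ecdysone receptor (Bombyx mori), read by a luciferase reporter, with a stated time of 24 h; on this read-out higher numbers stand for an effect only at larger amounts of compound and lower numbers for an effect already at smaller amounts.

Of the compounds shown here, two carry numbers so far. Compound 1, `CC(C)(C)N(NC(=O)c1ccccc1)C(=O)c1ccccc1F`, gives 309 nM in this assay. Compound 2, `Cc1ccccc1C(=O)NN(C(=O)c1ccccc1Cl)C(C)(C)C`, gives 72.4 nM in this assay, the lower of the two values and beyond the scatter from compound 1, so compound 2 stands as the stronger agonist of the pair on the evidence to hand. Among the compounds with values here, no single-point step between compound 1 and compound 2 has been computed; the two structures differ in more than one place, so their two values are simply noted side by side.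

The next compound, compound 3, `CC(C)(C)N(NC(=O)c1ccc(Cl)cc1)C(=O)c1ccccc1Cl`, is not yet measured in this assay. Against compound 2 it differs as follows: 4-chlorophenyl in place of 2-methylphenyl on a carbonyl carbon.

Within the data shown here, no measured step of this kind exists, so the expectation rests on the two values alone. With compound 2 at 72.4 nM as the anchor, compound 3 is expected to land close to it, with a step of a 1.4-fold lower number from compound 2 to compound 3 (0.16 log units; within the scatter) that is estimated to be small and, if anything, toward a lower number. The estimate for compound 3 in this assay is 50 nM, with a range from 15 nM to 200 nM.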

Compound 3, half-maximal effective concentration: 115 nM
The estimate for compound 3 lay 2.3-fold (0.36 log units) below the measured number, and the stated range covers the measured number.
By their numbers in this assay, from the lowest: compounds 2 and 3 (each within the scatter of the next); then compound 1.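

Within the data shown here, on the carbonyl carbon whose other neighbour is the amide-type nitrogen, replacing 2-methylphenyl with 4-chlorophenyl gives a 1.6-fold higher number from compound 2 to compound 3 (0.20 log units; within the scatter) in this assay as the first single-place reading, and it does not separate the two groups beyond the scatter. The swap changes both the substituent on the phenyl ring and its printed ring number, yet neither group carries a hydrogen-bond donor, acceptor or net charge, so this pair says nothing about groups that do, and the two changes cannot be told apart within this one step. No measurement at hand explains why these two groups read alike.

As far as these compounds go, whether 4-methylphenyl at this place would read with compound 2 and compound 3 remains open, and that comparison would take the two parts of the swap apart. Also open, from the compounds shown here alone, is whether an amine, a carboxylic acid or a longer alkyl chain on the phenyl ring at this place would stay within the scatter of compound 2 in this assay or move clearly away from it.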